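The compounds below may be only part of what the source reports. "The series", "measured", "known", "first", "only" and "open" are said of these compounds alone.

Working notes on the shared core and its substituent at the five-membered ring. Three analogues have been measured in an assay for inhibition of Fatty-acid amide hydrolase 1 (Rattus norvegicus); on this read-out higher numbers stand for weaker inhibition and lower numbers for stronger inhibition. Compound 1 `COC(=O)c1ccc(-c2cnc(C(=O)CCc3ccc(-c4ccccc4)cc3)o2)nc1` gives 2.2 nM, compound 2 `CS(=O)(=O)c1cnc(C(=O)CCc2ccc(-c3ccccc3)cc2)o1` gives 1.2 nM, and compound 3 `N#Cc1cccc(-c2cnc(C(=O)CCc3ccc(-c4ccccc4)cc3)o2)n1` gives 2.9 nM. Compound 3 therefore shows the highest of the three numbers: the step of a 1.3-fold higher number from compound 1 to compound 3 (0.12 log units; within the scatter) lies within the scatter, whereas the step of a 2.4-fold higher number from compound 2 to compound 3 (0.38 log units; beyond the scatter) is modest but beyond it; the step of a 1.8-fold lower number from compound 1 to compound 2 (0.26 log units; within the scatter) is within the scatter.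

Compound 4 `COC(=O)c1cnc(C(=O)CCc2ccc(-c3ccccc3)cc2)o1` is the next analogue; the change from compound 3 is methoxycarbonyl in place of 6-cyanopyridin-2-yl on an aromatic carbon. The step that bears on it most is a 2.4-fold higher number from compound 2 to compound 3 (0.38 log units; beyond the scatter), in which a small group on the same ring carbon was exchanged for a pyridyl and the number rose; compound 4 reverses that sense, returning to a small group. The step of a 1.8-fold lower number from compound 1 to compound 2 (0.26 log units; within the scatter) also points to a small group giving, if anything, a lower number. A modest fall is therefore expected, of the size a 1.9-fold lower number from compound 3 to compound 4 (0.29 log units; within the scatter). For compound 4 the expected value in this assay is 1.5 nM, with a range from 0.6 nM to 4 nM.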

Compound 4, inhibition constant: 1.5 nM
Beside the measured number, compound 4's estimate shows no gap at the digits printed; the range from low to high includes it.
By their numbers in this assay, from the lowest: compounds 2, 4, 1 and 3 (each within the scatter of the next, the first and the last beyond it).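

Compound 4 puts methoxycarbonyl, a group with no ring, on the aromatic carbon next to the ring oxygen. In this assay all three of its steps lie within the scatter: a 1.9-fold lower number from compound 3 to compound 4 (0.29 log units; within the scatter) and a 1.3-fold higher number from compound 2 to compound 4 (0.10 log units; within the scatter) and also a 1.5-fold lower number from compound 1 to compound 4 (0.17 log units; within the scatter) in the same series. At this position methoxycarbonyl therefore cannot be told apart from methylsulfonyl, 6-cyanopyridin-2-yl or 5-(methoxycarbonyl)pyridin-2-yl, and the removal of the pyridine ring gives no step beyond the scatter. No measurement at hand accounts for this narrow spread.

Going by these compounds, it remains open whether an amine, a carboxylic acid or a longer alkyl chain on this carbon would stay in the same range. Also open, on these data alone, is whether an unsubstituted ring carbon here would do so.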